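The source may hold more compounds than are shown below. What is called first, only, known or untested is meant among the compounds shown, and "the series" means these compounds.

Compound 2 `CC(C)=CC1C(C(=O)OCC2COCCOCCOCCOCCOCCO2)C1(C)C` is one of three crown-ether esters examined in a functional assay on HBL-100 cells (Homo sapiens) for inhibition, read by sulforhodamine B assay, with a stated time of 48 h; on this read-out lower numbers stand for stronger inhibition of growth and higher numbers for weaker inhibition of growth. In this assay compound 2 gives 40000 nM. Compound 3 `O=C(OCC1COCCOCCOCCOCCOCCO1)c1cccc(-c2ccc(Br)cc2)c1`, which carries a bromophenyl-substituted benzoate in place of the terpenoid acid, gives 6400 nM in this assay. Compound 1 `O=C(CCCCC1CCCCC1)OCC1COCCOCCOCCOCCO1` reaches only a limit of this assay, at > 100000 nM, so that the limit of > 100000 nM in this assay, at which 1 of the 3 values shown sits, stands as the weakest result among the three. Among the two numbers that are numbers rather than limits, compound 2 therefore stands highest, and its distance to compound 3 lies beyond the scatter of repeated measurements.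

Compound 4 `O=C(OCC1COCCOCCOCCOCCOCCO1)c1cccnc1` has not yet been measured in this assay. It differs from compound 2 in one place: pyridin-3-yl in place of 2,2-dimethyl-3-(2-methylprop-1-en-1-yl)cyclopropyl on a carbonyl carbon. With compound 1 and compound 2 both weak and only compound 3 clearly stronger, no large change in either direction is expected from this exchange, and any step from compound 2 to compound 4 is expected to stay within the usual scatter, a 1.3-fold higher number from compound 2 to compound 4 (0.10 log units; within the scatter). Compound 4 is accordingly estimated at 50000 nM in this assay, with a plausible range from 12000 nM to 200000 nM, and a real chance that only a limit is reported.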

Compound 4, concentration for 50% growth inhibition: > 100000 nM
Compound 4 was reported as a limit (the forecaster's own chance of this, stated with the estimate: 35%); middle value at least 2.0-fold (0.30 log units) from the limit.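

In this assay, the exchange of 2,2-dimethyl-3-(2-methylprop-1-en-1-yl)cyclopropyl for pyridin-3-yl on the carbonyl carbon gives an at least 2.5-fold higher number from compound 2 to compound 4 (0.39 log units; beyond the scatter), so this position responds to the group it carries even though compound 2 is itself weak. The size of this step is only a lower bound, as compound 4 is reported as a limit and not as a number. With compound 4, the limit now recurs in the series: the limit of > 100000 nM in this assay, at which 2 of the 4 values shown sit.

The compounds shown leave open how much activity is lost with pyridin-3-yl, and whether the loss follows from the departure of the cyclopropyl group or the entry of the ring nitrogen. Going by these compounds, whether an unsubstituted phenyl on the same carbonyl carbon would behave like pyridin-3-yl or like the group in compound 2 also remains open.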